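The source may report more compounds than this note shows. Statements on the series, on what has been measured and on what is new or still open speak of the compounds shown alone.

Measured so far in a functional assay on MCF7 cells (Homo sapiens) for antiproliferative activity, read by MTT assay, with a stated time of 72 h (on this read-out lower numbers stand for stronger inhibition and higher numbers for weaker inhibition), are:
- compound 1 `CCN(c1ccc(C)cc1)S(=O)(=O)C1CC2OC1C(c1ccc(NC(=O)CCCCCCC(=O)O)cc1)=C2c1ccc(O)cc1` at 42300 nM
- compound 2 `CCN(c1cccc(OC)c1)S(=O)(=O)C1CC2OC1C(c1ccc(NC(=O)CCCCCCC(=O)O)cc1)=C2c1ccc(O)cc1` at 37400 nM

Compound 2 stands within the scatter of compound 1, so neither ranks ahead. The change to compound 3 `CCN(c1ccc(O)cc1)S(=O)(=O)C1CC2OC1C(c1ccc(NC(=O)CCCCCCC(=O)O)cc1)=C2c1ccc(O)cc1` is 4-hydroxyphenyl in place of 3-methoxyphenyl on a sulfonamide nitrogen and puts 4-hydroxyphenyl in place of 3-methoxyphenyl on a sulfonamide nitrogen. Among the measured compounds shown here, the one measured step at that nitrogen is a 1.1-fold lower number from compound 1 to compound 2 (0.05 log units; within the scatter) and stays within the scatter. No step beyond the scatter is therefore expected in this assay for this change. The expected step is a 1.0-fold higher number from compound 2 to compound 3 (0.01 log units; within the scatter) as a working estimate. For compound 3 the estimate is 38000 nM with an expected range from 18000 nM to 80000 nM on this read-out.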

Compound 3, half-maximal inhibitory concentration: 46600 nM
Beside the measured number, compound 3's estimate is 1.2-fold (0.09 log units) below it; the measured number falls inside the stated range.
By their numbers in this assay, from the lowest: compounds 2, 1 and 3 (each within the scatter of the next).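

In this assay, a hydroxy group on the phenyl ring at the sulfonamide nitrogen fits the flat picture so far: 4-hydroxyphenyl in place of 3-methoxyphenyl gives a 1.2-fold higher number from compound 2 to compound 3 (0.10 log units; within the scatter), and hydroxy in place of methyl on an aromatic carbon gives a 1.1-fold higher number from compound 1 to compound 3 (0.04 log units; within the scatter). A hydrogen-bond donor on this ring therefore brings no step beyond the scatter, and the three phenyl groups cannot be ranked. No evidence is available to explain this flatness.

Still open, going by these compounds, is whether an amine or a carboxylic acid on this phenyl ring, or a longer chain in place of ethyl on the same nitrogen, would give a step beyond the scatter.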